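Exchanging the Pyrrolidine for Dimethylamino in Compound 4

A few compounds are considered here, and "the series" means these few. Any claim that something is new, unique, unknown or untested is made for them only; others in the source may bear on it.

Compound 1 `O=c1cc(-c2ccccc2)oc2cc(O)c(OCCCN3CCCC3)c(O)c12` yields only a limit in a functional assay on HepG2 cells (Homo sapiens) for antiproliferative activity, read by MTT assay, with a stated time of 48 h (on this read-out higher numbers stand for weaker inhibition and lower numbers for stronger inhibition), reported as > 100000 nM; this is the limit of > 100000 nM in this assay, at which 1 of the 3 values shown sits. Compound 2 `O=c1cc(-c2ccccc2)oc2cc(OCc3ccccc3)c(OCCCN3CCCC3)c(O)c12` gives 4200 nM, and the change is an at least 23-fold lower number from compound 1 to compound 2 (1.37 log units; beyond the scatter). Compound 3 `COc1cc2oc(-c3ccccc3)cc(=O)c2c(O)c1OCCCN1CCN(C)CC1` differs from compound 2 in several places at once; compound 3 gives 15100 nM. Of the two numbers shown, compound 2 holds the lower one. Compound 4 `CN(C)CCCOc1c(OCc2ccccc2)cc2oc(-c3ccccc3)cc(=O)c2c1O` differs from compound 2 by dimethylamino in place of pyrrolidin-1-yl on a saturated chain carbon, three bonds along the chain from an oxygen on an aromatic ring. Going by the values given here, the single measured step concerns the benzyl group and leaves the amine untouched, so it offers no guidance on this change, and no step beyond the scatter is expected. Compound 4 is therefore estimated at 5000 nM, with a range from 2000 nM to 12500 nM, an expected step of a 1.2-fold higher number from compound 2 to compound 4 (0.08 log units; within the scatter).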

Compound 4, half-maximal inhibitory concentration: 2200 nM
Beside the measured number, compound 4's estimate is 2.3-fold (0.36 log units) above it, and the stated range covers the measured number.
By their numbers in this assay, from the lowest: compounds 4 and 2 (each within the scatter of the next); then compound 3. At a limit, above all of these: compound 1.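

Replacing 3-(pyrrolidin-1-yl)propyl with 3-(dimethylamino)propyl gives, in this assay, a 1.9-fold lower number from compound 2 to compound 4 (0.28 log units; within the scatter), so at this position the ring on the amine can be given up without a step beyond the scatter. This is the first single change shown that touches the amine, and it holds for this one pair only. Nothing measured here bears on why the two amines read alike. On these data alone, it remains open how a morpholine or a longer chain would read at this place. As far as these compounds go, it is also open whether the benzyl group counts for as much alongside dimethylamino as it does alongside pyrrolidin-1-yl.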